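The source may report more compounds than this note shows. Statements on the series, on what has been measured and on what is new or still open speak of the compounds shown alone.

Three compounds share one core and differ only in the group carried on an aromatic carbon of the sulfonamide-bearing ring. Compound 1 `COc1ccc(N2C[C@@H](C)N[C@@H](C)C2)cc1NS(=O)(=O)c1ccc(-c2cc(Cl)ccc2F)cc1` gives 0.501 nM in a functional assay for agonist activity at growth hormone secretagogue receptor type 1 (Homo sapiens), read by FLIPR; a higher number here means that more compound is needed for the effect, a lower number that less compound is needed. Compound 2 `COc1ccc(N2C[C@@H](C)N[C@@H](C)C2)cc1NS(=O)(=O)c1ccc(-n2cccn2)cc1` gives 15.9 nM, and compound 3 `COc1ccc(N2C[C@@H](C)N[C@@H](C)C2)cc1NS(=O)(=O)c1ccc(-c2cccs2)cc1` gives 3.98 nM. Among these three numbers compound 3 stands second highest: the step of a 4.0-fold lower number from compound 2 to compound 3 (0.60 log units; beyond the scatter) separates it from compound 2, and the step of a 7.9-fold higher number from compound 1 to compound 3 (0.90 log units; beyond the scatter) from compound 1, while a 32-fold higher number from compound 1 to compound 2 (1.50 log units; beyond the scatter) spans the whole set.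

Compound 4 `COc1ccc(N2C[C@@H](C)N[C@@H](C)C2)cc1NS(=O)(=O)c1ccc(OCc2ccccc2)cc1` differs from compound 3 in one place: benzyloxy in place of thiophen-2-yl on an aromatic carbon. For the measured compounds named here, no measured step replaces a five-membered aromatic group with a benzyloxy group, so the bearing of the three measured steps is indirect. They show that exchanging the group on this carbon moves the number from a modest to a large extent, without telling which way a benzyloxy group would go. Compound 4 is therefore expected near compound 3, with the estimated step of a 1.6-fold higher number from compound 3 to compound 4 (0.20 log units; within the scatter) and a wide range. The estimate for compound 4 in this assay is 6.3 nM, between 1.5 nM and 25 nM.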

Compound 4, half-maximal effective concentration: 100 nM
For compound 4 the middle estimate is 16-fold (1.20 log units) below the measured one, outside the stated range (above it).
By their numbers in this assay, from the lowest: compound 1; then compound 3; then compound 2; then compound 4.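

In this assay the benzyloxy group gives the highest number of the series at this aromatic carbon, with a 25-fold higher number from compound 3 to compound 4 (1.40 log units; beyond the scatter) and a 6.3-fold higher number from compound 2 to compound 4 (0.80 log units; beyond the scatter) and a 200-fold higher number from compound 1 to compound 4 (2.30 log units; beyond the scatter). Until now, only aromatic rings joined directly to this carbon had been seen, and benzyloxy, which holds its six-membered aromatic ring away through an oxygen and a carbon, extends the range well beyond theirs, although thiophen-2-yl and benzyloxy carry the same count of hydrogen-bond donors and acceptors. Nothing available explains this rise.

The compounds shown do not separate the contribution of the oxygen from that of the added carbon, and a phenoxy group or a phenethyl chain would bear on that. From the compounds shown here alone, whether an amine or a carboxylic acid on this carbon would be tolerated also remains open.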